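A few compounds are considered here, and "the series" means these few. Any claim that something is new, unique, unknown or untested is made for them only; others in the source may bear on it.

Of the compounds shown here, three that share one core have been measured in an assay on microsomes from liver for inhibition of acyl-CoA desaturase 1 (Rattus norvegicus); on this read-out higher numbers stand for weaker inhibition and lower numbers for stronger inhibition. Compound 1 `CC(=O)c1ccccc1OC1CCN(c2ccc(-n3ccnc3)nn2)CC1` gives 34 nM, compound 2 `COc1ccccc1OC1CCN(c2ccc(-n3ccnc3)nn2)CC1` gives 543 nM, and compound 3 `Cc1cccc(OC2CCN(c3ccc(-n4ccnc4)nn3)CC2)c1` gives 251 nM. Compound 3 thus holds the second highest number of the three: it sits a 2.2-fold lower number from compound 2 to compound 3 (0.34 log units; beyond the scatter) away from compound 2, while the step of a 7.4-fold higher number from compound 1 to compound 3 (0.87 log units; beyond the scatter) is larger. The remaining measured step, a 16-fold higher number from compound 1 to compound 2 (1.20 log units; beyond the scatter), concerns the other two compounds only.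

Compound 4 `FC(F)(F)c1cccc(OC2CCN(c3ccc(-n4ccnc4)nn3)CC2)c1` differs from compound 3 in one spot: trifluoromethyl in place of methyl on an aromatic carbon. Among the compounds with values here, no measured step alters this methyl itself; the two steps that reach compound 3 each replace the whole substituted phenyl group rather than a single small group on it, so they say little about exchanging one small group for another on the same ring. What they do show is that changes on this phenyl group can move the number over a considerable span, in either direction. With nothing pointing one way, the expected step from compound 3 to compound 4 is a 1.0-fold lower number from compound 3 to compound 4 (0.00 log units; within the scatter), that is, nothing clearly beyond the scatter, with a wide range to cover the uncertainty. Compound 4 is therefore expected to give about 250 nM, somewhere between 90 nM and 700 nM.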

Compound 4, half-maximal inhibitory concentration: 19 nM
For compound 4 the middle estimate is 13-fold (1.12 log units) above the measured one, outside the stated range (below it).
By their numbers in this assay, from the lowest: compounds 4 and 1 (each within the scatter of the next); then compound 3; then compound 2.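

In this assay, within the data shown here, exchanging methyl for trifluoromethyl gives a 13-fold lower number from compound 3 to compound 4 (1.12 log units; beyond the scatter), and this is the first step here in which one small group changes while the rest of the phenyl group stays as it was. The earlier steps shown here replaced the whole substituted phenyl group, so they could not show how much a single group on this aromatic carbon matters on its own, whereas this step shows that such an exchange alone can move the number by a large amount. Nothing measured here says why this exchange goes with stronger inhibition.

The compounds shown give only two groups on this carbon, so they leave open whether other small groups, such as a chlorine atom, a nitrile or an ethyl group, would follow trifluoromethyl or methyl, and a single pair cannot show a trend. Going by these compounds, it also remains open whether trifluoromethyl would give a similar step at the place the acetyl group holds in compound 1, or on a phenyl group carrying a second substituent.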